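A few compounds are considered here, and "the series" means these few. Any claim that something is new, unique, unknown or untested is made for them only; others in the source may bear on it.

Measured compounds:
compound 1, `CCCCCNC(=O)/N=C(\N)NCCCc1sc(N)nc1C`, 0.78
compound 2, `Cc1nc(N)sc1CCCN/C(N)=N/C(=S)N[C@@H](C)c1ccccc1`, 0.65

In a functional assay on Right cardiac atrium for agonist activity at histamine H2 receptor (Cavia porcellus), with a stated time of 30 min, in the presence of a further agent that is not named here (on this read-out higher numbers stand for larger maximal responses and lower numbers for smaller maximal responses), compound 1 gives 0.78. Compound 2 gives 0.65 in this assay. Of the two numbers, compound 1 holds the higher, and the gap to compound 2 lies beyond the usual scatter of repeated measurements. The two measured compounds differ from one another in more than one place, so nothing more than these two values can be read from the pair.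

Compound 3, `Cc1nc(N)sc1CCCN/C(N)=N/C(=O)NCc1ccco1`, has not yet been measured in this assay. It differs from compound 1 in a single place: furan-2-yl in place of butyl on a saturated chain carbon bound to an amide-type nitrogen. Going by the values given here, with no single-point step between measured compounds to lean on, the expected change from compound 1 is judged only from the values in hand. The step a number 0.060 lower from compound 1 to compound 3 (within the scatter) is expected to be small, downward if anything, and not clearly beyond the scatter. Compound 3 is therefore estimated to give 0.72 in this assay, with a range from 0.55 to 0.9.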

Compound 3, intrinsic activity: the largest response reached, as a fraction of the reference agonist's: 0.58
Compound 3: the middle estimate sits 0.14 above what was measured, within the range that was stated.
By their numbers in this assay, from the lowest: compounds 3 and 2 (each within the scatter of the next); then compound 1.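

Going by these compounds alone, on the saturated chain carbon bound to an amide-type nitrogen, furan-2-yl in place of butyl gives the first single-place step in this set, and in this assay that change brings a number 0.20 lower from compound 1 to compound 3 (beyond the scatter) and so a real loss of maximal response. This shows that the largest response reached in this assay depends on what stands at this place, and that an open butyl chain and a five-membered aromatic ring with one hetero atom cannot be exchanged here without a shift beyond the usual scatter. No measurement in hand bears on why the response falls with this change.

With one step at this place, the compounds shown cannot separate the effect of having a ring from the effect of this particular ring, a question that a cyclopentyl, phenyl or thiophen-2-yl group at the same carbon would address. On these data alone, it also remains open whether the value of compound 1, 0.78, is a peak or a point on a slope, which a shorter propyl chain or a longer hexyl chain in place of butyl would show.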